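This account rests on a few compounds, and the source may have more. Where it says the series, first, only, none or still open, it means among the compounds named here.

Among the compounds with values here, in an ADME assay on KB cells (Homo sapiens) for cytotoxicity (a lower number here means a stronger inhibitor, a higher number a weaker inhibitor), compound 1 `CC(C)[C@@H](CO)Nc1ccc2ncc(-c3ccc(C#N)cc3)n2n1` gives 52200 nM, the higher of the two numbers measured so far, and compound 2 `CC(C)[C@@H](CO)Nc1ccc2ncc(-c3ccc(C(N)=O)cc3)n2n1` gives 13000 nM. Compound 3 `N#Cc1ccc(-c2cnc3ccc(N[C@H]4CC[C@H](O)CC4)nn23)cc1` keeps the cyano group of compound 1 and changes the group on the nitrogen: 4-hydroxycyclohexyl in place of 1-(hydroxymethyl)-2-methylpropyl on a nitrogen on an aromatic ring. Within the data shown here, the only measured step, a 4.0-fold lower number from compound 1 to compound 2 (0.60 log units; beyond the scatter), replaces cyano with carbamoyl and leaves that nitrogen group untouched, so it is a loose guide to size and says nothing firm on direction. A small move to a lower number is therefore expected, estimated as a 1.6-fold lower number from compound 1 to compound 3 (0.21 log units; within the scatter). For compound 3 the expected value is 32000 nM, within an estimated range of 10000 nM to 90000 nM.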

Compound 3, half-maximal inhibitory concentration: 24000 nM
Estimate against measurement, compound 3: 1.3-fold (0.12 log units) above; low and high end bracket the measured number.
By their numbers in this assay, from the lowest: compounds 2 and 3 (each within the scatter of the next); then compound 1.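

Changing the group on the nitrogen gives a 2.2-fold lower number from compound 1 to compound 3 (0.34 log units; beyond the scatter) in this assay and so shows that this position, like the cyano site, can shift the number. The change brings in a six-membered non-aromatic ring where the leaving group has no ring, but these compounds cannot show whether the ring, the hydroxyl's placement or something else matters. No measured evidence explains the shift. Still open, as far as these compounds go, is how an amine in place of the hydroxyl on the cyclohexyl ring would read, and whether this nitrogen change would give a similar step alongside carbamoyl rather than cyano.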